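A Sulfonate Replaces a Triazole Thioether at the Chain Carbon

The compounds below may be only part of what the source reports. "The series", "measured", "known", "first", "only" and "open" are said of these compounds alone.

Measured compounds:
compound 1 `O=[N+]([O-])c1ccc(-c2nc(CO[C@@H]3O[C@H](CO)[C@H]4OC5(CCCC5)O[C@@H]34)no2)cc1` gives 17000 nM in a functional assay on HBL-100 cells (Homo sapiens) for antiproliferative activity, read by sulforhodamine B assay, with a stated time of 48 h; on this read-out lower numbers stand for stronger inhibition of growth and higher numbers for weaker inhibition of growth
compound 2 `O=[N+]([O-])c1ccc(-c2nc(CO[C@@H]3O[C@H](CSc4ncn[nH]4)[C@H]4OC5(CCCC5)O[C@@H]34)no2)cc1` gives 24000 nM in this assay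

Compound 2 holds the highest of the two numbers; its nearest neighbour is compound 1, a difference that lies within the scatter. Compound 3 `Cc1ccc(S(=O)(=O)OC[C@H]2O[C@@H](OCc3noc(-c4ccc([N+](=O)[O-])cc4)n3)[C@@H]3OC4(CCCC4)O[C@@H]32)cc1` carries ((4-methylphenyl)sulfonyl)oxy in place of (1H-1,2,4-triazol-5-yl)sulfanyl on a saturated chain carbon bound to a saturated ring carbon. Going by the values given here, the only measured step at this position, a 1.4-fold higher number from compound 1 to compound 2 (0.15 log units; within the scatter), was within the scatter, and it offers no sign that a change at this chain carbon moves the number much. Compound 3 is therefore expected to stay close to compound 2, with a 1.2-fold lower number from compound 2 to compound 3 (0.08 log units; within the scatter). The estimate for compound 3 is 20000 nM, with a range from 7000 nM to 55000 nM.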

Compound 3, concentration for 50% growth inhibition: > 100000 nM
Compound 3 was reported as a limit; the forecaster's own chance of this, stated with the estimate: 10%; middle value at least 5.0-fold (0.69 log units) from the limit.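

In this assay compound 3 is reported only as a limit, not as a number: the limit of > 100000 nM in this assay, at which 1 of the 3 values shown sits. The chain carbon is therefore not indifferent to what it carries, as the earlier pair alone might have suggested: ((4-methylphenyl)sulfonyl)oxy in place of (1H-1,2,4-triazol-5-yl)sulfanyl gives an at least 4.1-fold higher number from compound 2 to compound 3 (0.61 log units; beyond the scatter). (4-Methylphenyl)sulfonyl in place of hydrogen on the oxygen gives an at least 5.8-fold higher number from compound 1 to compound 3 (0.76 log units; beyond the scatter), so both steps mean weaker inhibition of growth beyond the scatter. From the compounds shown here alone, how far the true value of compound 3 lies past its limit remains open. So does whether an amine or a carboxylic acid at this chain carbon would stay close to compound 1 and compound 2 or fall with compound 3.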